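Chain Lengthening on a Stilbene-like Core: Compounds 1 to 4

The source may hold more compounds than are shown below. What is called first, only, known or untested is meant among the compounds shown, and "the series" means these compounds.

Measured compounds:
- compound 1, `CC=C(/C=C/c1ccc(OC)c(N)c1)c1cc(OC)c(OC)c(OC)c1`, gives 137 nM in a functional assay on A2780 cells (Homo sapiens) for antiproliferative activity, read by MTT assay, with a stated time of 48 h; on this read-out higher numbers stand for weaker inhibition and lower numbers for stronger inhibition
- compound 2, `CCC=C(/C=C/c1ccc(OC)c(N)c1)c1cc(OC)c(OC)c(OC)c1`, gives 248 nM in this assay
- compound 3, `CCC=C(/C(C)=C/c1ccc(OC)c(O)c1)c1cc(OC)c(OC)c(OC)c1`, gives 5290 nM in this assay

Compound 1 and compound 2 differ in one place only: methyl in place of hydrogen on a saturated chain carbon bound to a double-bonded chain carbon. This change gave a 1.8-fold higher number from compound 1 to compound 2 (0.26 log units; within the scatter), a step that stays within the usual scatter of repeated measurements, so the two compounds cannot be told apart on this read-out.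

Compound 3 carries a core that differs from the core of compound 1 in more than one place; the difference between the two cores is not broken down here. What the numbers show is that compound 3 stands far from both, with a number beyond the scatter above compound 2 and compound 1 alike.

Compound 4, `CCCC=C(/C(C)=C/c1ccc(OC)c(O)c1)c1cc(OC)c(OC)c(OC)c1`, has not been measured. It differs from compound 3 as follows: methyl in place of hydrogen on a saturated chain carbon, two bonds along the chain from a double-bonded chain carbon. Among the compounds with values here, this is the same kind of change as the one from compound 1 to compound 2, but not the same change, since there the added methyl sat on a saturated chain carbon bound to a double-bonded chain carbon, whereas here it sits two bonds along the chain from a double-bonded chain carbon.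

Because a 1.8-fold higher number from compound 1 to compound 2 (0.26 log units; within the scatter) lay within the scatter, a similar small step is expected from compound 3 to compound 4, namely a 1.5-fold higher number from compound 3 to compound 4 (0.18 log units; within the scatter). Compound 4 is therefore expected to give about 8000 nM in this assay, with a range from 3500 nM to 18000 nM.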

Compound 4, half-maximal inhibitory concentration: 2930 nM
The estimate for compound 4 lay 2.7-fold (0.44 log units) above the measured number; measured number outside the range, below it.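

In this assay, adding the methyl gave a 1.8-fold lower number from compound 3 to compound 4 (0.26 log units; within the scatter), a step too small for compound 3 and compound 4 to be told apart on this read-out. Taken alone, each of the two steps in this series looks negligible, yet set side by side they do not match, so this kind of change cannot be assumed to carry over unchanged from one core to the other: the same change on two cores in this assay, a 1.8-fold higher number (0.26 log units; within the scatter) from compound 1 to compound 2 and a 1.8-fold lower number (0.26 log units; within the scatter) from compound 3 to compound 4, 3.3-fold (0.51 log units) apart, beyond the scatter of two such steps. These steps do not show what lies behind that gap, as the cores differ in more than one place and the added methyl also sits in a different place, on a saturated chain carbon bound to a double-bonded chain carbon in one pair and two bonds along the chain from a double-bonded chain carbon in the other, and one pair on each core cannot separate these differences.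

Still open, as far as these compounds go, is whether the same methyl, added in the same place on each core, would give matching steps, and how a longer chain such as butyl would read on either core. Also open, from the compounds shown here alone, is what a cyclopropyl ring or a fluorine atom in place of this chain would do.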